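Working notes: dimethylcarbamoyl to 1-methyl-1H-imidazol-4-yl on the shared core

This account rests on a few compounds, and the source may have more. Where it says the series, first, only, none or still open, it means among the compounds named here.

- compound 1 `CC(=O)c1nc([C@@H](O)[C@H](O)[C@H](O)CO)c(-c2ccccc2)[nH]1` gives 23.9 mL/min/kg in the series
- compound 2 `CN(C)C(=O)c1nc([C@@H](O)[C@H](O)[C@H](O)CO)c[nH]1` gives 11.3 mL/min/kg in the series

In an in vivo ADME assay on the whole organism (strain 129/SvEvBrd x C57BL/6) for pharmacokinetics, with Mus musculus as the target, at a dose of 1 mg/kg by the intravenous route (a lower number here means slower removal, a higher number faster removal of the compound), compound 2 stands lowest of the two measured compounds at 11.3 mL/min/kg and compound 1 lies higher at 23.9 mL/min/kg by a gap beyond the usual scatter. Compound 3 `Cn1cnc(-c2nc([C@@H](O)[C@H](O)[C@H](O)CO)c[nH]2)c1` differs from compound 2 in one place. The change 1-methyl-1H-imidazol-4-yl in place of dimethylcarbamoyl on an aromatic carbon puts 1-methyl-1H-imidazol-4-yl in place of dimethylcarbamoyl on an aromatic carbon. For the measured compounds named here, no measured pair shows this change, so the expectation is weakly founded. A small rise that stays within the scatter is expected, the estimated 1.3-fold higher number from compound 2 to compound 3 (0.12 log units; within the scatter) being modest. The estimate for compound 3 is 15 mL/min/kg with an expected range from 6 mL/min/kg to 32 mL/min/kg in this assay once measured.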

Compound 3, clearance: 9.1 mL/min/kg
For compound 3 the middle estimate is 1.6-fold (0.22 log units) above the measured one; the measured number falls inside the stated range.
By their numbers in this assay, from the lowest: compounds 3 and 2 (each within the scatter of the next); then compound 1.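

In this assay putting 1-methyl-1H-imidazol-4-yl in place of dimethylcarbamoyl on this aromatic carbon gives a 1.2-fold lower number from compound 2 to compound 3 (0.09 log units; within the scatter) and so leaves clearance unchanged within the scatter. For the compounds shown here, this is the first pair that differs in one place, and it shows that this position takes a five-membered aromatic ring as readily as dimethylcarbamoyl. No measured evidence bears on why the two groups match here. As far as these compounds go, whether a carboxylic acid or a primary amine on the same aromatic carbon would keep clearance at this level remains open.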